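A Bigger Group on the Oxygen Next to the Carbonyl

The compounds below may be only part of what the source reports. "The series", "measured", "known", "first", "only" and "open" are said of these compounds alone.

Going by the values given here, compound 2 `CCCCCCCCCCCCOc1ccc(NC(=O)ON=C(C)C)cc1` has the highest number of the two compounds measured so far: in an assay on H4 cells for inhibition of Fatty-acid amide hydrolase 1 (Homo sapiens) (a higher number here means a weaker inhibitor, a lower number a stronger inhibitor), compound 2 gives 5 nM. Among the compounds with values here, its only measured neighbour is compound 1 `CCCCCCCCOc1ccc(NC(=O)ON=C(C)C)cc1`, which in this assay gives 2.4 nM, and the step of a 2.1-fold higher number from compound 1 to compound 2 (0.32 log units; beyond the scatter) is the sole measured step in the set. That step concerns the chain on the far side of the shared core, not the part of the molecule that now changes. Compound 3 `CCCCCCCCCCCCOc1ccc(NC(=O)O/N=C/c2ccccc2)cc1` differs from compound 2 by a group of 8 heavy atoms (7 carbon, 1 nitrogen; one six-membered aromatic ring of carbon only) in place of a group of 4 heavy atoms (3 carbon, 1 nitrogen; no ring), on an oxygen next to a carbonyl group. Within the data shown here, no measured step touches this oxygen next to the carbonyl group, so there is nothing in the numbers that speaks directly to this change; the one measured step is modest and lies elsewhere. Given that, a step of a 1.6-fold higher number from compound 2 to compound 3 (0.20 log units; within the scatter) in this assay is expected, with the direction uncertain and a wide range allowed. For compound 3 the estimate in this assay is 8 nM, with a range from 1.5 nM to 40 nM.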

Compound 3, half-maximal inhibitory concentration: 2.4 nM
The estimate for compound 3 lay 3.3-fold (0.52 log units) above the measured number, within the range that was stated.
By their numbers in this assay, from the lowest: compounds 1 and 3 (each within the scatter of the next); then compound 2.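

In this assay, the exchange on an oxygen next to a carbonyl group gives a 2.1-fold lower number from compound 2 to compound 3 (0.32 log units; beyond the scatter) and so shows that this position accepts a group of 8 heavy atoms with one six-membered aromatic ring of carbon only in place of a group of 4 heavy atoms with no ring, without any loss of inhibition. Going by these compounds alone, the step is modest but beyond the scatter, and it points toward stronger inhibition, the opposite direction to the one measured step on the chain at the far side of the shared core. No measured evidence is available to explain the gain.

A single exchange cannot separate the effect of the ring from that of the larger group as a whole, and a cyclohexyl ring, a pyridine ring or a phenyl ring bearing a chlorine atom would help to tell these apart. Also open, going by these compounds, is whether the same exchange would give a similar step on the shorter chain of compound 1.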